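The source may report more compounds than this note shows. Statements on the series, on what has been measured and on what is new or still open speak of the compounds shown alone.

Of the compounds shown here, two of the shared core have been measured in an assay on TT cells for inhibition of proto-oncogene tyrosine-protein kinase receptor Ret variant C634W (Homo sapiens), read by MTT assay, with a stated time of 10 days (on this read-out lower numbers stand for stronger inhibition of growth and higher numbers for weaker inhibition of growth), so far. Compound 1 `CC(C)n1nc(-c2cc(C3CCCCC3)on2)c2c(N)ncnc21` carries cyclohexyl on an aromatic carbon; in this assay compound 1 returns only a limit of the assay, > 10000 nM. For the measured compounds named here, compound 2 `CC(C)n1nc(-c2ccon2)c2c(N)ncnc21` carries hydrogen in place of that cyclohexyl and is the only member of the pair with an actual number: in this assay compound 2 gives 7920 nM. Going by the values given here, the single step available, an at least 1.2-fold lower number from compound 1 to compound 2 (0.10 log units; that floor lies within the scatter), has a floor that lies inside the scatter, so the data do not settle whether the cyclohexyl changes growth inhibition beyond the scatter; what they show is that compound 1 sits at the limit of > 10000 nM in this assay, at which 1 of the 2 values shown sits.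

Compound 3 `CC(C)n1nc(-c2cc(C(C)(C)C)on2)c2c(N)ncnc21` has not been measured. It differs from compound 2 by tert-butyl in place of hydrogen on an aromatic carbon. The step from compound 1 to compound 2 is the only measured one that bears on this change, since it also exchanges a bulky carbon group and hydrogen on an aromatic carbon, and it was small at most. Compound 3 is therefore expected to move toward a higher number, a 1.5-fold higher number from compound 2 to compound 3 (0.18 log units; within the scatter), with a real chance that the assay again reports only a limit. The estimate for compound 3 in this assay is 12000 nM, between 5000 nM and 30000 nM.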

Compound 3, concentration for 50% growth inhibition: > 10000 nM
Compound 3: only a limit was reported; the forecaster's own chance of this, stated with the estimate: 50%; the middle value does not contradict the limit.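

In this assay compound 3 gives > 10000 nM, which is a limit of the assay and not a number. Tert-butyl in place of hydrogen, on the aromatic carbon next to the ring oxygen, gives an at least 1.2-fold higher number from compound 2 to compound 3 (0.10 log units; that floor lies within the scatter), so this change, like the cyclohexyl change before it, has a floor inside the scatter and does not settle whether a carbon group here alters growth inhibition beyond the scatter. What is new is that a group with no ring, and not only cyclohexyl, ends at the limit, which leaves the hydrogen compound as the only one at this position with an actual number, and the step between the two limit compounds cannot be read: the limit of > 10000 nM in this assay, at which 2 of the 3 values shown sit.

Still open, going by these compounds, is the true size of the tert-butyl and cyclohexyl changes, and with it whether either group raises the number beyond the scatter at all. Also open, on these data alone, is how a smaller group such as methyl, or an amine or a carboxylic acid, would read on this carbon, including whether any group here could bring the number below that of compound 2.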